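Extending the amide substituent from propyl to cyclobutyl

The source may report more compounds than this note shows. Statements on the series, on what has been measured and on what is new or still open speak of the compounds shown alone.

Compound 1: `CN(C(=O)c1ccccc1OCc1ccccc1)[C@@H]1CCC[C@H](N)C1`, 3150 nM
Compound 2: `CCCN(C(=O)c1ccccc1OCc1ccccc1)[C@@H]1CCC[C@H](N)C1`, 1230 nM

In an assay on HEK293 cells for inhibition of transient receptor potential cation channel subfamily M member 8 (Homo sapiens), read by FLIPR and calcium flux (on this read-out lower numbers stand for stronger inhibition and higher numbers for weaker inhibition), compound 2 gives the lowest of the two numbers, with compound 1 the nearest at a higher number. Compound 3, `N[C@H]1CCC[C@@H](N(C(=O)c2ccccc2OCc2ccccc2)C2CCC2)C1`, differs from compound 2 by cyclobutyl in place of propyl on an amide-type nitrogen. Within the data shown here, the only step that bears on this change is a 2.6-fold lower number from compound 1 to compound 2 (0.41 log units; beyond the scatter), which shows growth at this nitrogen lowering the number. Compound 3 is therefore expected to give about 800 nM in this assay, within 300 nM to 2500 nM, a step of a 1.5-fold lower number from compound 2 to compound 3 (0.19 log units; within the scatter).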

Compound 3, half-maximal inhibitory concentration: 1360 nM
Beside the measured number, compound 3's estimate is 1.7-fold (0.23 log units) below it; measured number inside the range.
By their numbers in this assay, from the lowest: compounds 2 and 3 (each within the scatter of the next); then compound 1.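

In this assay, cyclobutyl in place of propyl on the amide-type nitrogen gives a 1.1-fold higher number from compound 2 to compound 3 (0.04 log units; within the scatter) and so no separation between the ring and the open chain at this position. Cyclobutyl in place of methyl gives a 2.3-fold lower number from compound 1 to compound 3 (0.36 log units; beyond the scatter) and so, like propyl, stands apart from methyl beyond the scatter. Nothing measured here explains this result.

The compounds shown leave open whether a butyl chain or a cyclohexyl ring on this nitrogen would stay level with propyl and cyclobutyl or move the number further.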